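Arylurea thymidine analogues: cytotoxicity sits at the ceiling

This account rests on a few compounds, and the source may have more. Where it says the series, first, only, none or still open, it means among the compounds named here.

Measured compounds:
compound 1 `Cc1cn([C@@H]2C[C@H](O)[C@@H](CNC(=O)Nc3ccc(Br)cc3)O2)c(=O)[nH]c1=O` — a limit, > 50000 nM
compound 2 `COc1ccc(NC(=O)NC[C@H]2O[C@H](n3cc(C)c(=O)[nH]c3=O)C[C@@H]2O)cc1` — a limit, > 50000 nM
compound 3 `Cc1cn([C@@H]2C[C@H](O)[C@@H](CNC(=O)Nc3ccc(OC4CCOCC4)cc3)O2)c(=O)[nH]c1=O` — a limit, > 50000 nM

In an ADME assay on MRC5 cells (Homo sapiens) for cytotoxicity (on this read-out higher numbers stand for lower toxicity in this test and lower numbers for higher toxicity in this test), compound 3 is known only as a limit. The same holds for compound 1 and for compound 2, so all three values sit at the ceiling (the limit of > 50000 nM in this assay, at which 3 of the 3 values shown sit), and none of the steps between them can be read: a step that the two limits leave unreadable from compound 1 to compound 2, a step that the two limits leave unreadable from compound 1 to compound 3, a step that the two limits leave unreadable from compound 2 to compound 3. Within the shared core compound 3 therefore stands level with the other two as far as the numbers go.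

Compound 4 `Cc1cn([C@@H]2C[C@H](O)[C@@H](CNC(=O)Nc3ccc(Cc4ccccc4)cc3)O2)c(=O)[nH]c1=O` is the next member. The change is benzyl in place of (oxan-4-yl)oxy on an aromatic carbon. Among the measured compounds shown here, no measured step carries a readable size, so the only bearing the three steps have is that exchanges of the group on this aromatic carbon — bromo, methoxy, (oxan-4-yl)oxy — all left the value at the limit.

The expectation for compound 4 is a step of a number no higher from compound 3 to compound 4 (the limit leaves the size open), none beyond the scatter. Compound 4 is estimated at 50000 nM, with a range from 20000 nM to 100000 nM, most likely again reported as a limit.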

Compound 4, half-maximal cytotoxic concentration: > 50000 nM
Compound 4 ended at the assay's limit; the forecaster's own chance of this, stated with the estimate: 80%; the middle value sits exactly at the limit.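

In this assay compound 4 gives > 50000 nM, a limit. Among the compounds shown here, no step from compound 1, compound 2 or compound 3 to compound 4 can be read, as every value stands at the same ceiling: the limit of > 50000 nM in this assay, at which 4 of the 4 values shown sit. The compounds shown leave open whether any group on this aromatic carbon moves the value in this assay, and where each compound's actual value lies.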